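This account rests on a few compounds, and the source may have more. Where it says the series, first, only, none or still open, it means among the compounds named here.

Compound 1 `COc1cc(/C=C/C(=O)C2=C(/C=C/c3ccc(O)c(OC)c3)NC(=O)NC2c2ccccc2O)ccc1O` and compound 2 `COc1cc(/C=C/C(=O)C2=C(/C=C/c3ccc(O)c(OC)c3)NC(=O)NC2c2ccc(N(C)C)cc2)ccc1O` share one core and differ in a single place: 4-(dimethylamino)phenyl in place of 2-hydroxyphenyl on a saturated ring carbon. In a functional assay, with a stated time of 20 min, tested at 50 uM (a lower number here means a weaker effect, a higher number a stronger effect of the compound at the concentration tested), compound 1 gives 88%, and compound 2 gives 89.2%; the step of a number 1.2 percentage points higher from compound 1 to compound 2 (within the scatter). Compound 3 `COc1cc(/C=C/C(=O)C2=C(/C=C/c3ccc(O)c(OC)c3)NC(=S)NC2c2ccccc2O)ccc1O` rests on a core whose difference from the core of compound 1 is not broken down here; in this assay compound 3 gives 88.5%, a number within the scatter of both compound 1 and compound 2. Compound 4 `COc1cc(/C=C/C(=O)C2=C(/C=C/c3ccc(O)c(OC)c3)NC(=S)NC2c2ccc(N(C)C)cc2)ccc1O` has not yet been measured and differs from compound 3 by the same change: 4-(dimethylamino)phenyl in place of 2-hydroxyphenyl on a saturated ring carbon. Compound 4 is expected to show a step of a number 1 percentage points higher from compound 3 to compound 4 (within the scatter) in this assay, because the earlier step of a number 1.2 percentage points higher from compound 1 to compound 2 (within the scatter) stayed within the scatter. Compound 4 is accordingly estimated at 89.5%, with a likely range from 82% to 95%.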

Compound 4, a percentage reported as activity, at one concentration (the size of the read-out at that concentration, not a potency): 84%
Compound 4: the middle estimate sits 5.5 percentage points above what was measured; the measured number falls inside the stated range.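

In this assay, putting 4-(dimethylamino)phenyl in place of 2-hydroxyphenyl on the core of compound 3 gives a step of a number 4.5 percentage points lower from compound 3 to compound 4 (within the scatter). Set beside the same change on the core of compound 1, the two steps do not differ: the same change on two cores in this assay, a number 1.2 percentage points higher (within the scatter) from compound 1 to compound 2 and a number 4.5 percentage points lower (within the scatter) from compound 3 to compound 4, 5.7 percentage points apart, within the scatter of two such steps. This shows that on these two cores the change stays within the scatter and that the read-out gives no sign of it behaving differently from one core to the other, but it does not show how the change would carry to other cores or at other concentrations.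

The compounds shown leave open whether a carboxylic acid or an amine on the phenyl ring would move the read-out beyond the scatter. They also leave open what a longer chain on the saturated ring carbon would do.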